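Cyclohexyl on the chain: from compound 2 to compound 4

The source may report more compounds than this note shows. Statements on the series, on what has been measured and on what is new or still open speak of the compounds shown alone.

Measured compounds:
compound 1 `CCCCCCCCCCCCS(=O)(=O)/C=C/c1ccc(O)c(O)c1` with 8500 nM
compound 2 `C=CCCCCCS(=O)(=O)/C=C/c1ccc(O)c(O)c1` with 7100 nM
compound 3 `O=S(=O)(/C=C/c1ccc(O)c(O)c1)CC1CCCCC1` with 7500 nM

All three share a core in which a catechol-bearing double bond is joined to a sulfonyl group, and they differ only in the saturated chain carried on the other side of that sulfur. In a functional assay, read by fluorescence and spectrophotometry, with a stated time of 1 h (on this read-out lower numbers stand for an effect already at smaller amounts and higher numbers for an effect only at larger amounts of compound), compound 2 gives the lowest of the three numbers, yet both of its neighbours lie within the usual scatter of it, so no order among the three can be read from these values.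

Compound 4 `O=S(=O)(/C=C/c1ccc(O)c(O)c1)CCCC1CCCCC1` is not yet measured. It differs from compound 2 by cyclohexyl in place of but-3-en-1-yl on a saturated chain carbon, three bonds along the chain from a sulfonyl sulfur. Going by the values given here, two measured steps bear on this change. The step of a 1.2-fold lower number from compound 1 to compound 2 (0.08 log units; within the scatter) shortened the chain with no shift beyond the scatter, and the step of a 1.1-fold higher number from compound 2 to compound 3 (0.02 log units; within the scatter) brought a cyclohexyl onto the chain, again with no shift beyond the scatter. Compound 4 moves the cyclohexyl three bonds along the chain from a sulfonyl sulfur, a change of the same kind as these. No step beyond the scatter is therefore expected in this assay.

Compound 4 is estimated at 7500 nM, with a range from 4000 nM to 14000 nM, which means an expected step of a 1.1-fold higher number from compound 2 to compound 4 (0.02 log units; within the scatter).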

Compound 4, half-maximal effective concentration: 7900 nM
Compound 4: the middle estimate sits 1.1-fold (0.02 log units) below what was measured, within the range that was stated.
By their numbers in this assay, from the lowest: compounds 2, 3, 4 and 1 (each within the scatter of the next).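

In this assay, the step of a 1.1-fold higher number from compound 2 to compound 4 (0.05 log units; within the scatter) shows that this place, three bonds along the chain from a sulfonyl sulfur, takes cyclohexyl in place of but-3-en-1-yl with no shift beyond the scatter, even though a ring of carbon enters and the double bond of the chain leaves. The earlier compounds showed cyclohexyl only on the saturated chain carbon bound to the sulfonyl sulfur, so the result extends that finding to a second place on the chain, and among these four compounds neither a change of chain, a double bond nor a ring has yet separated one number from another. Nothing available here explains why these changes leave the number within the scatter.

Going by these compounds, the groups on this chain are all built of carbon and hydrogen alone, so what an amine or a carboxylic acid would do at this place stays open. On these data alone, whether a very short chain such as methyl, or a phenyl ring in place of cyclohexyl, would give a step beyond the scatter also stays open.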